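Swapping Fluoro for Cyclohexyl on a Fatty Acid Receptor Agonist

A few compounds are considered here, and "the series" means these few. Any claim that something is new, unique, unknown or untested is made for them only; others in the source may bear on it.

Of the compounds shown here, three share one core and have been measured in an assay on isolated protein for agonist activity at Free fatty acid receptor 1 (Homo sapiens); a lower number here means that less compound is needed, a higher number that more compound is needed for the effect. Compound 1 `CC#CC(CC(=O)O)c1ccc(OCc2ccc3nc(-c4ccc(C(C)C)cc4)cn3c2)cc1` gives 528 nM. Compound 2 `CC#CC(CC(=O)O)c1ccc(OCc2ccn3cc(-c4ccc(F)cc4)nc3c2)cc1` gives 783 nM. Compound 3 `CC#CC(CC(=O)O)c1ccc(OCc2ccc3nc(-c4ccccc4)cn3c2)cc1` gives 979 nM. Compound 2 stands second highest of these three numbers, and its gaps to compound 3 and to compound 1 both lie within the scatter, so the three are indistinguishable on these data.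

Compound 4 `CC#CC(CC(=O)O)c1ccc(OCc2ccn3cc(-c4ccc(C5CCCCC5)cc4)nc3c2)cc1` differs from compound 2 in one place: cyclohexyl in place of fluoro on an aromatic carbon. The closest measured step is a 1.9-fold higher number from compound 1 to compound 3 (0.27 log units; within the scatter), where an alkyl group on the same kind of aromatic carbon, para to a large group, was removed without a step beyond the scatter. Fluoro to cyclohexyl is a larger swap than that, and no measured pair tests a cyclohexyl, so the expectation rests on one step only.

Compound 4 is therefore expected to show a 1.6-fold lower number from compound 2 to compound 4 (0.19 log units; within the scatter), a step not clearly beyond the scatter, with an estimated 500 nM and a range from 180 nM to 1500 nM.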

Compound 4, half-maximal effective concentration: 559 nM
For compound 4 the middle estimate is 1.1-fold (0.05 log units) below the measured one, and the stated range covers the measured number.
By their numbers in this assay, from the lowest: compounds 1, 4, 2 and 3 (each within the scatter of the next).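

In this assay, putting cyclohexyl where the fluoro stood brings a full six-membered non-aromatic ring in place of a single atom, and the result is a 1.4-fold lower number from compound 2 to compound 4 (0.15 log units; within the scatter). Within the data shown here, this position, on an aromatic carbon para to a large group, therefore accepts a much bulkier group on this core without a step beyond the scatter, something the earlier compounds could not show, as none carried anything larger there than isopropyl. Nothing measured here bears on the reason for this result.

Still open, going by these compounds, is whether an amine, a carboxylic acid or a longer alkyl chain at this position would also stay within the scatter of compound 2. On these data alone, it is also open whether cyclohexyl would give a similar result on the core of compound 1.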